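This account rests on a few compounds, and the source may have more. Where it says the series, first, only, none or still open, it means among the compounds named here.

Measured so far:
- compound 1, `COc1ccc(/C=C/C[C@H]2C[C@H]([C@H](O)c3ccc(OC)c(OC)c3)CO[C@@H]2c2ccc(OC)c(OC)c2)cc1OC`: 23500 nM
- compound 2, `O[C@@H](c1ccccc1)[C@H]1CO[C@H](c2ccccc2)[C@@H](C/C=C/c2ccccc2)C1`: 7040 nM
- compound 3, `Oc1ccc(/C=C/C[C@H]2C[C@@H]([C@@H](O)c3ccccc3)CO[C@@H]2c2ccccc2)cc1`: 7380 nM

In a functional assay on HL-60 cells (Homo sapiens) for cytotoxicity, read by WST assay, with a stated time of 48 h (on this read-out higher numbers stand for weaker inhibition and lower numbers for stronger inhibition), compound 3 gives 7380 nM, which is the second highest of the three numbers. Its nearest neighbour is compound 2 at 7040 nM; the two values sit within the scatter of each other, so no order between them is claimed. Among the measured compounds shown here, compound 1, which carries methoxy groups on each of its aromatic rings, gives the highest number, 23500 nM; no single-point step links it to compound 3, so only the two values themselves are compared here.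

Compound 4, `COc1ccc(/C=C/C[C@H]2C[C@@H]([C@@H](O)c3ccccc3)CO[C@@H]2c2ccccc2)cc1`, is not yet measured. It differs from compound 3 by methyl in place of hydrogen on an oxygen on an aromatic ring.

For the measured compounds named here, the only measured step, a 1.0-fold higher number from compound 2 to compound 3 (0.02 log units; within the scatter), concerns the oxygen-bearing group on the same aromatic ring and left the number unchanged within the scatter. Whether capping that oxygen with methyl behaves alike is not shown by any measured pair; compound 1, with methoxy groups throughout, gives the highest number, but it differs from compound 3 in several places at once. Adding methyl to the oxygen of compound 3 is therefore expected to give a step of a 1.2-fold higher number from compound 3 to compound 4 (0.09 log units; within the scatter) in this assay, not beyond the scatter, with a wider range to allow for the lack of a direct precedent. Compound 4 is estimated at 9000 nM, between 3500 nM and 22000 nM.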

Compound 4, half-maximal inhibitory concentration: 9010 nM
Estimate against measurement, compound 4: 1.0-fold (0.00 log units) below, within the range that was stated.
By their numbers in this assay, from the lowest: compounds 2, 3 and 4 (each within the scatter of the next); then compound 1.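

Capping the oxygen on the aromatic ring with methyl, which turns 4-hydroxyphenyl into 4-methoxyphenyl, gives a 1.2-fold higher number from compound 3 to compound 4 (0.09 log units; within the scatter) in this assay and so supplies a direct reading for this change, which the earlier pair could not give. Methoxy in place of hydrogen on the aromatic carbon gives a 1.3-fold higher number from compound 2 to compound 4 (0.11 log units; within the scatter) and stands alongside a 1.0-fold higher number from compound 2 to compound 3 (0.02 log units; within the scatter) for hydroxy, so hydrogen, hydroxy and methoxy at this place are not told apart by this read-out. No supporting data bear on why the number stays within the scatter across these three groups.

On these data alone, whether an amine or a carboxylic acid on this aromatic carbon, or a longer chain such as ethoxy on the oxygen, would also stay within the scatter of compound 3 remains open. Among the compounds shown here, no single step reaches compound 1, which differs from the others in several places at once; which of those places goes with compound 1 giving 23500 nM in this assay stays unsettled.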